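A few compounds are considered here, and "the series" means these few. Any claim that something is new, unique, unknown or untested is made for them only; others in the source may bear on it.

The series is built on the shared core of compound 1 `COc1cc2c(cc1OC)C(CC(=O)O)CC2`, an acid that in a functional assay on the whole organism (strain Wistar) for inhibition, with Rattus norvegicus as the target, read by paw edema, with a stated time of 6 h, at a dose of 100 mg/kg (a higher number here means more inhibition at the dose given (going by the name of the read-out), a lower number less inhibition), gives 20.4%. Compound 2 `COc1cc2c(cc1OC)C(CC(=O)Nc1cccc(Cl)c1)CC2` carries a (3-chlorophenyl)amino in place of hydroxy on the carbonyl carbon, and in this assay compound 2 gives 38.9%. Compound 3 `COc1cc2c(cc1OC)C(CC(=O)Nc1ccccc1C)CC2`, with a (2-methylphenyl)amino at the same place, gives 25.9% in this assay; it stands second highest of the three numbers, close to compound 1 and clearly under compound 2. The step of a number 5.5 percentage points higher from compound 1 to compound 3 (within the scatter) lies within the scatter, whereas a number 18.5 percentage points higher from compound 1 to compound 2 (beyond the scatter) lies beyond it, as does a number 13 percentage points lower from compound 2 to compound 3 (beyond the scatter).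

Compound 4 `COc1cc2c(cc1OC)C(CC(=O)Nc1cccc(C)c1)CC2` has not yet been measured in this assay. It differs from compound 3 by 3-methylphenyl in place of 2-methylphenyl on an amide-type nitrogen. Among the measured compounds shown here, the one measured step that touches the aryl on the amide-type nitrogen is a number 13 percentage points lower from compound 2 to compound 3 (beyond the scatter), where the 3-chlorophenyl of compound 2 gave the higher number. Since compound 4 carries a 3-methylphenyl, sharing its substitution pattern with the 3-chlorophenyl of compound 2 though with methyl rather than chloro, a modest rise is expected for compound 4, smaller than that step. The expected step is a number 7.1 percentage points higher from compound 3 to compound 4 (within the scatter). Compound 4 is therefore estimated at 33%, with a range from 21% to 45%.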

Compound 4, a percentage reported as inhibition, in the whole organism at one dose (the size of the read-out at that dose, not a potency): 38%
Beside the measured number, compound 4's estimate is 5 percentage points below it, and the stated range covers the measured number.
By their numbers in this assay, from the lowest: compounds 1 and 3 (each within the scatter of the next); then compounds 4 and 2 (each within the scatter of the next).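

Exchanging 2-methylphenyl for 3-methylphenyl on the amide-type nitrogen joins the same atoms differently, yet in this assay it gives a number 12.1 percentage points higher from compound 3 to compound 4 (beyond the scatter), so where the methyl sits on this aryl matters to the read-out, something compounds 2 and 3 could not show because they differ in the substituent as well as in its place. Methyl in place of chloro on the aromatic carbon gives a number 0.9 percentage points lower from compound 2 to compound 4 (within the scatter), so among the compounds shown, the identity of this substituent makes no difference beyond the scatter when the aryl is a 3-substituted phenyl. The step from the acid, a number 17.6 percentage points higher from compound 1 to compound 4 (beyond the scatter), shows that a second 3-substituted anilide stands clear of compound 1, while compound 3, with its 2-methylphenyl, goes against any general gain from replacing the acid with an anilide.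

Still open, going by these compounds, is how a plain phenyl, or a methoxy or trifluoromethyl group in place of the methyl, would behave on this amide-type nitrogen, and whether the gaps hold at other doses. Nothing available here explains why the place of the methyl matters.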